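Pyridyl variation on the oxazole ketone series

The source may report more compounds than this note shows. Statements on the series, on what has been measured and on what is new or still open speak of the compounds shown alone.

Compound 2 `NC(=O)c1cccc(-c2cnc(C(=O)CCc3ccc(-c4ccccc4)cc3)o2)n1` gives 1.2 nM in an assay for inhibition of Fatty-acid amide hydrolase 1 (Rattus norvegicus) (a higher number here means a weaker inhibitor, a lower number a stronger inhibitor), the lowest of the two numbers shown, while compound 1 `COC(=O)c1ccc(-c2cnc(C(=O)CCc3ccc(-c4ccccc4)cc3)o2)nc1` gives 2.2 nM; the step of a 1.8-fold lower number from compound 1 to compound 2 (0.26 log units; within the scatter) stays within the scatter. Compound 3 `COC(=O)c1ccc(-c2cnc(C(=O)CCc3ccc(-c4ccccc4)cc3)o2)cn1` carries 6-(methoxycarbonyl)pyridin-3-yl in place of 6-carbamoylpyridin-2-yl on an aromatic carbon. Going by the values given here, only that single step, which exchanged a methoxycarbonyl pyridine for a carbamoyl pyridine without a change beyond the scatter, bears on this move, and compound 3 returns to a methoxycarbonyl pyridine. The expected step of a 1.7-fold higher number from compound 2 to compound 3 (0.22 log units; within the scatter) is therefore none beyond the scatter. Compound 3 is estimated at 2 nM, within 0.7 nM to 6 nM.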

Compound 3, inhibition constant: 0.6 nM
The estimate for compound 3 lay 3.3-fold (0.52 log units) above the measured number; measured number below the stated range.
By their numbers in this assay, from the lowest: compounds 3, 2 and 1 (each within the scatter of the next, the first and the last beyond it).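

In this assay, the pyridine attachment at this position now gives a change beyond the scatter: with the methoxycarbonyl group retained, the move to 6-(methoxycarbonyl)pyridin-3-yl gives a 3.7-fold lower number from compound 1 to compound 3 (0.56 log units; beyond the scatter). Replacing 6-carbamoylpyridin-2-yl, with its hydrogen-bond donor, by this donor-free group gives a 2.0-fold lower number from compound 2 to compound 3 (0.30 log units; within the scatter). No evidence on hand accounts for either step.

As far as these compounds go, that second step changes both the substituent and its ring placement, so their separate contributions remain open. Also open, from the compounds shown here alone, is how a carboxylic acid or a primary amide would fare on the pyridin-3-yl ring of compound 3.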